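A few compounds are considered here, and "the series" means these few. Any claim that something is new, unique, unknown or untested is made for them only; others in the source may bear on it.

The measured compounds:
compound 1, `CCNCCC(=O)Nc1cccc2c1CN(C)CC2c1ccccc1`, in a functional assay on the whole organism for inhibition, with Mus musculus as the target (on this read-out higher numbers stand for an effect only at larger amounts of compound and lower numbers for an effect already at smaller amounts), a limit only, > 160 mg/kg
compound 2, `CCCCNCCC(=O)Nc1cccc2c1CN(C)CC2c1ccccc1`, in this assay 74 mg/kg
compound 3, `CCNCC(=O)Nc1cccc2c1CN(C)CC2c1ccc(C)cc1`, in this assay 5.6 mg/kg

Compound 1 and compound 2 differ by a single change, (ethyl in place of hydrogen on a saturated chain carbon, two bonds along the chain from an amine nitrogen). On this change the read-out moved by an at least 2.1-fold lower number from compound 1 to compound 2 (0.33 log units; beyond the scatter). The size of that step is known only as a bound because compound 1 sits at the limit of > 160 mg/kg in this assay, at which 1 of the 3 values shown sits, so the true step may be larger than the figure given.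

Compound 3 has the same atoms as compound 1 joined differently; the difference between the two cores is not broken down here. Of the two numbers available in this assay compound 3 gives the lower one, and compound 2 is the nearest to it, the gap between them lying beyond the scatter.

Compound 4, `CCCCNCC(=O)Nc1cccc2c1CN(C)CC2c1ccc(C)cc1`, is not yet measured. It differs from compound 3 by ethyl in place of hydrogen on a saturated chain carbon, two bonds along the chain from an amine nitrogen, the same change as that made between compound 1 and compound 2, at the same place. The expectation for compound 4 therefore rests on the earlier step, an at least 2.1-fold lower number from compound 1 to compound 2 (0.33 log units; beyond the scatter), applied to the value of compound 3, 5.6 mg/kg. A step of a 2.4-fold lower number from compound 3 to compound 4 (0.39 log units; beyond the scatter) is expected. Compound 4 is thus estimated to give about 2.3 mg/kg in this assay, with a likely range from 0.8 mg/kg to 6 mg/kg.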

Compound 4, dose for half-maximal effect: about 2.5 mg/kg
Compound 4: the middle estimate sits 1.1-fold (0.04 log units) below what was measured, and the stated range covers the measured number.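

In this assay, ethyl in place of hydrogen on a saturated chain carbon, two bonds along the chain from an amine nitrogen, gave a 2.2-fold lower number from compound 3 to compound 4 (0.35 log units; beyond the scatter), so the change that lowered the number on the core of compound 1 also lowered it on the core of compound 3. Set side by side, the two steps compare as follows: the same change on two cores in this assay, an at least 2.1-fold lower number (0.33 log units; beyond the scatter) from compound 1 to compound 2 and a 2.2-fold lower number (0.35 log units; beyond the scatter) from compound 3 to compound 4; the limit leaves it open whether they differ. The direction of the change therefore carried over between these two cores, but this does not show that its size was preserved or that it would carry over to any further core, since the earlier step starts from compound 1, which stands at a limit rather than at a number: the limit of > 160 mg/kg in this assay, at which 1 of the 4 values shown sits.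

The compounds shown leave open how far the trend from ethylamino to butylamino runs, as neither a propyl group nor a longer chain such as hexyl on the amine nitrogen appears among them, and neither does a ring-closed amine such as piperidine. They also leave open whether a different replacement for the methyl group on the phenyl ring of compound 3, such as chlorine, would keep the same step in this assay.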